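From bromo to hydroxy on the shared core

This account rests on a few compounds, and the source may have more. Where it says the series, first, only, none or still open, it means among the compounds named here.

Compound 1 `Nc1nc2c(nc(I)n2COCCO)c(=O)[nH]1`: 111000 nM
Compound 2 `Nc1nc2c(nc(N)n2COCCO)c(=O)[nH]1`: > 200000 nM, a limit of the assay
Compound 3 `Nc1nc2c(nc(Br)n2COCCO)c(=O)[nH]1`: > 200000 nM, a limit of the assay

These three compounds were tested in an ADME assay on L1210/0 cells (Mus musculus) for cytotoxicity, with a stated time of 48 h (on this read-out lower numbers stand for stronger inhibition and higher numbers for weaker inhibition), and they differ only in one group on an aromatic carbon of the shared core. Compound 3 gives no number and stands at > 200000 nM, which is a limit. It has company there, for the set shows (the limit of > 200000 nM in this assay, at which 2 of the 3 values shown sit).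

Compound 4 `Nc1nc2c(nc(O)n2COCCO)c(=O)[nH]1` is still unmeasured. It carries hydroxy in place of bromo on an aromatic carbon, between two ring nitrogen atoms: hydroxy in place of bromo on an aromatic carbon.

Three measured swaps at this same carbon bear on the change. Amino in place of iodo gave an at least 1.8-fold higher number from compound 1 to compound 2 (0.25 log units; that floor lies within the scatter), and bromo in place of iodo gave an at least 1.8-fold higher number from compound 1 to compound 3 (0.25 log units; that floor lies within the scatter). Bromo in place of amino gave a step that the two limits leave unreadable from compound 2 to compound 3. None of these shows a step beyond the scatter, so none is expected here in this assay. The expected step is a number no higher from compound 3 to compound 4 (the limit leaves the size open). Compound 4 is estimated at 200000 nM, with an expected range from 100000 nM to 400000 nM, and it may well be reported only as a limit.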

Compound 4, half-maximal inhibitory concentration: > 200000 nM
Compound 4: only a limit was reported; the forecaster's own chance of this, stated with the estimate: 75%; the middle value sits exactly at the limit.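

In this assay, within the data shown here, compound 4 is a limit and not a number, and with it hydroxy joins amino and bromo as a third group on this aromatic carbon, between two ring nitrogen atoms, that gives only a limit, with compound 1 the one compound that goes against this: the limit of > 200000 nM in this assay, at which 3 of the 4 values shown sit. Hydroxy in place of iodo gives an at least 1.8-fold higher number from compound 1 to compound 4 (0.25 log units; that floor lies within the scatter), so the one new comparison that can be read still does not go beyond the scatter. The steps to compound 4 from compound 2 and from compound 3 cannot be read, as both ends of each are limits, and so the change from bromo to hydroxy shows no measurable effect in either direction.

Among these compounds, compound 1 at 111000 nM remains the only compound here with a number. This leaves open whether any group on this carbon other than iodo can give a reading short of the limit. As far as these compounds go, whether a chloro or a methylthio group on this carbon, or a longer chain in place of the (2-hydroxyethoxy)methyl group, would give a number in this assay also stays open.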